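Chloro on the anilino ring in a cytotoxicity test

A few compounds are considered here, and "the series" means these few. Any claim that something is new, unique, unknown or untested is made for them only; others in the source may bear on it.

Of the compounds shown here, two of the same core have been measured. Compound 1 `CC(=O)C[C@H]1O[C@@H](On2cc(CN3C(=O)/C(=N\Nc4ccccc4)c4ccccc43)nn2)[C@H](OC(C)=O)[C@@H](OC(C)=O)[C@@H]1OC(C)=O` and compound 2 `CC(=O)C[C@H]1O[C@@H](On2cc(CN3C(=O)/C(=N\Nc4ccccc4)c4ccccc43)nn2)[C@H](OC(C)=O)[C@@H](OC(C)=O)[C@H]1OC(C)=O` share every atom and bond and differ only in configuration as drawn (the fact that compounds 1 and 2 differ only in the configuration as drawn). In an ADME assay on Vero cells (Chlorocebus sabaeus) for cytotoxicity, read by fluorescence and resazurin assay, with a stated time of 3 days (on this read-out lower numbers stand for higher toxicity in this test and higher numbers for lower toxicity in this test), compound 1 gives 108000 nM, and compound 2 gives 65200 nM, the lower of the two numbers, though the step of a 1.7-fold lower number from compound 1 to compound 2 (0.22 log units; within the scatter) lies within the scatter, so the two stand level.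

Compound 3 `CC(=O)C[C@H]1O[C@@H](On2cc(CN3C(=O)/C(=N\Nc4cccc(Cl)c4)c4ccccc43)nn2)[C@H](OC(C)=O)[C@@H](OC(C)=O)[C@H]1OC(C)=O` comes from compound 2 by chloro in place of hydrogen on an aromatic carbon. Going by the values given here, the only measured step, from compound 1 to compound 2, touches configuration alone and says nothing about adding a chloro group, so no measured step bears on this change. The expectation is therefore a step of a 1.2-fold lower number from compound 2 to compound 3 (0.07 log units; within the scatter) of no size beyond the scatter, in either direction. For compound 3 in this assay the estimate is 55000 nM, between 22000 nM and 140000 nM.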

Compound 3, half-maximal cytotoxic concentration: 87900 nM
Estimate against measurement, compound 3: 1.6-fold (0.20 log units) below; measured number inside the range.
By their numbers in this assay, from the lowest: compounds 2, 3 and 1 (each within the scatter of the next).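

In this assay, chloro in place of hydrogen on the anilino ring gives a 1.3-fold higher number from compound 2 to compound 3 (0.13 log units; within the scatter) and so lies within the scatter, which means compound 2 and compound 3 stand level. Going by these compounds alone, the earlier compounds differed only in configuration, so this is the first view of a change on this ring, and here a single chlorine atom leaves the cytotoxicity read-out where it was. No available fact bears on the chloro change, so the data offer no account of this result.

As far as these compounds go, whether an amine, a methoxy group or a carboxylic acid at this same place would shift the number remains open, as does the effect of chloro elsewhere on this ring. From the compounds shown here alone, it is also open whether chloro would behave the same way on the configuration drawn in compound 1.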